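The source may report more compounds than this note shows. Statements on the series, on what has been measured and on what is new or still open speak of the compounds shown alone.

Measured compounds:
compound 1, `COc1cc2c(cc1CC=C(C)C)C(=O)C[C@@H](c1ccc(Oc3ccccc3)cc1)O2`, 46%
compound 2, `COc1cc2c(cc1CC1OC1(C)C)C(=O)C[C@@H](c1ccc(O)cc1)O2`, 79%

Both compounds were tested in a functional assay on A549 cells (Homo sapiens) for inhibition, read by sulforhodamine B assay, with a stated time of 48 h, tested at 50 uM; on this read-out lower numbers stand for less inhibition of growth and higher numbers for more inhibition of growth at the one concentration tested. Compound 1 gives 46%, and compound 2 gives 79%. Of the two numbers, compound 1 stands lowest; compound 2 lies above it by a margin beyond the usual scatter of this read-out. The two compounds differ in more than one place, so their gap is taken only as what the two values show and not as the effect of any single change.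

Compound 3, `CCCCOc1ccc([C@@H]2CC(=O)c3cc(CC=C(C)C)c(OC)cc3O2)cc1`, has not yet been measured in this assay. It differs from compound 1 in one place: butyl in place of phenyl on an oxygen on an aromatic ring. Among the compounds with values here, no measured pair in this set shares that change, so there is no step of known size to lean on. The account therefore expects compound 3 to stay near compound 1, with a step of a number 4 percentage points higher from compound 1 to compound 3 (within the scatter) that would not rise beyond the scatter in either direction. For compound 3 in this assay the estimate is 50%, within a range from 30% to 70%.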

Compound 3, percent growth inhibition at one concentration: 37%
Compound 3: the middle estimate sits 13 percentage points above what was measured; measured number inside the range.
By their numbers in this assay, from the lowest: compounds 3 and 1 (each within the scatter of the next); then compound 2.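

Within the data shown here, putting butyl in place of phenyl on an oxygen on an aromatic ring gives a number 9 percentage points lower from compound 1 to compound 3 (within the scatter) in this assay, the first step in this set that can be read at a single place. It shows that, at this position and at the one concentration tested, phenoxy and butoxy cannot be told apart, so a chain with no ring serves here as well as the six-membered aromatic ring of carbon does. Nothing on hand bears on why the two groups read alike.

The compounds shown leave open how this oxygen would read with other groups on it, such as a short methyl, a longer octyl chain, or a chain ending in an amine or a carboxylic acid. Compound 2, at 79%, differs from compound 1 and compound 3 in more than one place, so it leaves open whether a free hydroxyl at this position would change the reading at all.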